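A few compounds are considered here, and "the series" means these few. Any claim that something is new, unique, unknown or untested is made for them only; others in the source may bear on it.

Compound 2 `C/C=C\C(=O)Nc1cc(Nc2nc3c(c(-c4cn(C)c5ccc(F)cc45)n2)CSCC3)c(OC)cc1N(C)CCN(C)C` is the subject of this step. Among the compounds with values here, in a functional assay on A549 cells (Homo sapiens) for inhibition, read by MTT assay, with a stated time of 72 h (a higher number here means a weaker inhibitor, a lower number a stronger inhibitor), compound 2 gives 5310 nM, the highest of the two numbers measured so far; its nearest neighbour is compound 1 `C=CC(=O)Nc1cc(Nc2nc3c(c(-c4cn(C)c5ccc(F)cc45)n2)CSCC3)c(OC)cc1N(C)CCN(C)C`, which in this assay gives 4550 nM. The step from compound 1 to compound 2, a 1.2-fold higher number from compound 1 to compound 2 (0.07 log units; within the scatter), lies within the scatter. Compound 3 `CCC/C=C\C(=O)Nc1cc(Nc2nc3c(c(-c4cn(C)c5ccc(F)cc45)n2)CSCC3)c(OC)cc1N(C)CCN(C)C` has not yet been measured. It differs from compound 2 by ethyl in place of hydrogen on a saturated chain carbon bound to a double-bonded chain carbon. Within the data shown here, the only measured step bearing on this change is the one from compound 1 to compound 2, which also lengthened the chain on the carbonyl carbon and gave a 1.2-fold higher number from compound 1 to compound 2 (0.07 log units; within the scatter), so a lengthening of the same chain is expected to produce no step beyond the scatter, or at most a small rise. Compound 3 is therefore estimated at 6500 nM, within a range of 3000 nM to 14000 nM, which corresponds to an expected step of a 1.2-fold higher number from compound 2 to compound 3 (0.09 log units; within the scatter).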

Compound 3, half-maximal inhibitory concentration: 5190 nM
Estimate against measurement, compound 3: 1.3-fold (0.10 log units) above; measured number inside the range.
By their numbers in this assay, from the lowest: compounds 1, 3 and 2 (each within the scatter of the next).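

In this assay, ethyl in place of hydrogen on a saturated chain carbon bound to a double-bonded chain carbon gives a 1.0-fold lower number from compound 2 to compound 3 (0.01 log units; within the scatter) and stays within the scatter, while the full change from vinyl to pent-1-en-1-yl on the carbonyl carbon gives a 1.1-fold higher number from compound 1 to compound 3 (0.06 log units; within the scatter) and also stays within the scatter. The earlier single step covered only prop-1-en-1-yl, whereas the three compounds now show that this chain can carry pent-1-en-1-yl with no step beyond the scatter in this assay. No measured evidence is available to account for this result. Going by these compounds, it remains open whether a still longer chain, or a branched one, would give a step beyond the scatter. Also open, on these data alone, is what an amine or a carboxylic acid at the end of the chain would do to the number.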